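Aroyl for alkanoyl on the ring nitrogen of compound 3

A few compounds are considered here, and "the series" means these few. Any claim that something is new, unique, unknown or untested is made for them only; others in the source may bear on it.

Compound 3 `CCCCCCCCC(=O)N1c2ccccc2CCC1C(=O)Nc1ccccc1O` gives the highest number of the three measured in a functional assay on NUGC-3 cells (Homo sapiens) for cytotoxicity, read by sulforhodamine B assay, with a stated time of 72 h (a lower number here means a stronger inhibitor of growth, a higher number a weaker inhibitor of growth), at 31100 nM. Compound 1 `CCCCCCCCC(=O)N1c2ccccc2CCC1C(=O)Nc1ccccc1C(F)(F)F` gives 6180 nM, and compound 2 `O=C(Nc1ccccc1O)C1CCc2ccccc2N1` gives 2680 nM; the two steps into compound 3 read a 5.0-fold higher number from compound 1 to compound 3 (0.70 log units; beyond the scatter) and a 12-fold higher number from compound 2 to compound 3 (1.06 log units; beyond the scatter). Compound 4 `O=C(Nc1ccccc1O)C1CCc2ccccc2N1C(=O)c1cccc(Cl)c1` differs from compound 3 by 3-chlorophenyl in place of octyl on a carbonyl carbon. For the measured compounds named here, no measured pair exchanges one acyl group for another on that nitrogen; the only step touching it, a 12-fold higher number from compound 2 to compound 3 (1.06 log units; beyond the scatter), shows the octylcarbonyl group costing potency against the bare nitrogen of compound 2. A different acyl group may recover part of that, but nothing here sizes it. A shift no larger than the scatter is therefore expected, a 2.1-fold lower number from compound 3 to compound 4 (0.32 log units; beyond the scatter). Compound 4 is estimated at 15000 nM, with a range of 4000 nM to 50000 nM.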

Compound 4, concentration for 50% growth inhibition: 11000 nM
Compound 4: middle estimate off by 1.4-fold (0.13 log units), on the high side, within the range that was stated.
By their numbers in this assay, from the lowest: compound 2; then compounds 1 and 4 (each within the scatter of the next); then compound 3.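

In this assay, the acyl group on the ring nitrogen can be changed with an effect beyond the scatter: 3-chlorophenyl in place of octyl on the carbonyl carbon gives (a 2.8-fold lower number from compound 3 to compound 4 (0.45 log units; beyond the scatter)). The aromatic acyl group does not restore the value of the unacylated nitrogen, with (3-chlorophenyl)carbonyl in place of hydrogen giving (a 4.1-fold higher number from compound 2 to compound 4 (0.61 log units; beyond the scatter)). No measurement bears on the reason for either step.

As far as these compounds go, whether acetyl on that nitrogen would bring the number closer to that of compound 2 remains open. Also open, from the compounds shown here alone, is whether trifluoromethyl in place of hydroxy would lower the number with (3-chlorophenyl)carbonyl on that nitrogen, as it does with octylcarbonyl.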